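This account rests on a few compounds, and the source may have more. Where it says the series, first, only, none or still open, it means among the compounds named here.

Measured compounds in the series:

- compound 1 `COc1ccc(NC(=O)[C@H]2CCCN2C(=O)C(C)(C)c2ccc(Cl)cc2)cc1`: 50.1 nM
- compound 2 `O=C(Nc1ccc2[nH]c(=O)[nH]c2c1)[C@H]1CCCN1C(=O)C1(c2cccc(Cl)c2)CCCC1`: 0.398 nM
- compound 3 `COc1ccc(NC(=O)[C@H]2CCCN2C(=O)C2(c3ccc(Cl)cc3)CCC2)cc1`: 10 nM

All three numbers come from an assay on isolated protein for inhibition of histone acetyltransferase p300 (Homo sapiens), with a stated time of 60 min; a lower number here means a stronger inhibitor, a higher number a weaker inhibitor. On these, compound 2 stands lowest of the three; the nearest is compound 3, and the gap to it is beyond the scatter, as is the larger gap to compound 1. Compounds 1 and 3 share the same amide-side group and differ elsewhere, so their values say nothing about the amide-side change considered here.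

Compound 4 `O=C(Nc1ccc2[nH]nnc2c1)[C@H]1CCCN1C(=O)C1(c2cccc(Cl)c2)CCCC1` is not yet measured. Relative to compound 2 it carries a group of 9 heavy atoms (6 carbon, 3 nitrogen; one five-membered aromatic ring with 3 hetero atoms, one six-membered aromatic ring of carbon only) in place of a group of 10 heavy atoms (7 carbon, 2 nitrogen, 1 oxygen; one five-membered aromatic ring with 2 hetero atoms, one six-membered aromatic ring of carbon only), on an amide-type nitrogen. Among the measured compounds shown here, no measured pair shows a change of this kind, so the step from compound 2 to compound 4 in this assay can only be guessed. The two five-membered rings differ in the counted donors and acceptors, and the aryl-amide group is the part that separates compound 2 from compounds 1 and 3 by wide margins, so the expectation is a step upward, moderate in size, rather than none. The estimated value for compound 4 in this assay is 3 nM, with a range of 0.6 nM to 15 nM, which means an expected step of a 7.5-fold higher number from compound 2 to compound 4 (0.88 log units; beyond the scatter).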

Compound 4, half-maximal inhibitory concentration: 20 nM
Compound 4: the middle estimate sits 6.7-fold (0.82 log units) below what was measured, and the stated range ends below it.
By their numbers in this assay, from the lowest: compound 2; then compounds 3 and 4 (each within the scatter of the next); then compound 1.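

Working from the one single-place change in the series, the group on the amide-type nitrogen in this assay is not tolerant of this swap: a 50-fold higher number from compound 2 to compound 4 (1.70 log units; beyond the scatter), and it is a large step with the rest of the molecule held constant. Both groups keep a six-membered aromatic ring of carbon only, so the step goes with the change in the five-membered aromatic ring, where 2 hydrogen-bond donors and 1 hydrogen-bond acceptor give way to 1 hydrogen-bond donor and 2 hydrogen-bond acceptors, and the double bond outside the aromatic rings is lost. Nothing on hand ties the step to any one of these differences or gives a reason for it.

Still open, as far as these compounds go, is which of these differences carries the step, something an indazole or a benzimidazole without the carbonyl on the same amide-type nitrogen could help to separate. Among the compounds shown here, also open is how either group compares with the methoxyphenyl group of compound 1 and compound 3, as no pair changes that group alone.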